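Second chloro on the benzyl ring, carried across two cores

A few compounds are considered here, and "the series" means these few. Any claim that something is new, unique, unknown or untested is made for them only; others in the source may bear on it.

Compound 1 `Cn1c(=O)[nH]c2ccc(OCc3ccc(Cl)cc3)cc21` gives 56400 nM in an assay on cells for inhibition of Amine oxidase [flavin-containing] B (Homo sapiens), read by fluorescence, with stated times of 30 min and 15 min; on this read-out lower numbers stand for stronger inhibition and higher numbers for weaker inhibition. Compound 2 `Cn1c(=O)[nH]c2ccc(OCc3ccc(Cl)c(Cl)c3)cc21` differs from it by chloro in place of hydrogen on an aromatic carbon, and in this assay compound 2 gives 7680 nM; the step is a 7.3-fold lower number from compound 1 to compound 2 (0.87 log units; beyond the scatter). Compound 3 `O=C1Nc2ccc(OCc3cccc(Cl)c3)cc2C1=O` rests on another core; the difference between the two cores is not broken down here. In this assay compound 3 gives 46 nM, the lowest of the three numbers, beyond the scatter from both compound 2 and compound 1.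

Compound 4 `O=C1Nc2ccc(OCc3ccc(Cl)c(Cl)c3)cc2C1=O` is not yet measured. It differs from compound 3 by chloro in place of hydrogen on an aromatic carbon. This is the same kind of change as from compound 1 to compound 2, not the same: in compound 2 the entering chloro sits meta to a large group, in compound 4 para to a large group. For the measured compounds named here, the one measured instance of the change, a 7.3-fold lower number from compound 1 to compound 2 (0.87 log units; beyond the scatter), is the only basis, so a step of about that size is expected from compound 3 to compound 4, that is a 4.6-fold lower number from compound 3 to compound 4 (0.66 log units; beyond the scatter), with wider uncertainty for the different core. Compound 4 is estimated at 10 nM, expected between 3 nM and 40 nM.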

Compound 4, half-maximal inhibitory concentration: 3 nM
Estimate against measurement, compound 4: 3.3-fold (0.52 log units) above, within the range that was stated.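

In this assay the second chloro goes with a lower number on the second core as well, with a 15-fold lower number from compound 3 to compound 4 (1.19 log units; beyond the scatter) for this step, and the two steps agree in direction and, within the scatter, in size: the same change on two cores in this assay, a 7.3-fold lower number (0.87 log units; beyond the scatter) from compound 1 to compound 2 and a 15-fold lower number (1.19 log units; beyond the scatter) from compound 3 to compound 4, 2.1-fold (0.32 log units) apart, within the scatter of two such steps

This supports carrying the change between these two cores, but it rests on one pair per core and on a single end pattern, the two chloro groups of compound 2 and compound 4, so it is no general rule for the series. The pairs also differ in where the change happens: in compound 4 the entering chloro is para to a large group and ortho to a chloro group, whereas in compound 2 it stands differently relative to the large group, and the effects of place and core cannot be separated here.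

Open, from the compounds shown here alone, is whether the same step appears with a fluoro, a methoxy or a nitrile in place of the second chloro. Also open, going by these compounds, is how either core behaves with a benzyl ring carrying no chloro at all.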